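The source may report more compounds than this note shows. Statements on the series, on what has been measured and on what is new or still open speak of the compounds shown alone.

In a functional assay on MV4-11 cells (Homo sapiens) for inhibition, read by resazurin assay, with a stated time of 72 h (a higher number here means a weaker inhibitor of growth, a lower number a stronger inhibitor of growth), compound 1 (`COCCSc1nc(C)c(-c2ccnc(Nc3ccc(OC)cc3OC)n2)s1`) gives 810 nM and so lies within the scatter of compound 3 (`COc1ccc(Nc2nccc(-c3c[nH]c4ccccc34)n2)c(OC)c1`), which gives 600 nM as its number. Compound 2 (`COc1ccc(N(C)c2nccc(-c3cn(C)c4ccccc34)n2)c(OC)c1`) gives 2000 nM as a higher number, beyond the scatter from compound 1. Compound 4 (`COc1ccc(Nc2nccc(-c3sc(SCc4cccnc4)nc3C)n2)c(OC)c1`) has pyridin-3-yl in place of methoxymethyl on a saturated chain carbon bound to a sulfur. Among the measured compounds shown here, no measured pair differs in one place, so nothing shows directly what such a swap does in this assay for this series. The estimated step of a 1.6-fold lower number from compound 1 to compound 4 (0.21 log units; within the scatter) is expected to be small, toward a lower number and within the scatter. For compound 4 the expected value is estimated at 500 nM (150 nM to 1700 nM).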

Compound 4, concentration for 50% growth inhibition: 270 nM
Compound 4: middle estimate off by 1.9-fold (0.27 log units), on the high side; measured number inside the range.
By their numbers in this assay, from the lowest: compound 4; then compounds 3 and 1 (each within the scatter of the next); then compound 2.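

Putting pyridin-3-yl in place of methoxymethyl on a saturated chain carbon bound to a sulfur gives, in this assay, a 3.0-fold lower number from compound 1 to compound 4 (0.48 log units; beyond the scatter). Among the compounds shown here, this is the first step that can be read directly, and it shows that the number at this position responds to the change and that a six-membered aromatic ring is accepted there. Nothing given here explains the drop.

On these data alone, whether the ring itself or its nitrogen carries the step stays open. A phenyl or a pyridin-4-yl group at this place would separate the two.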